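Benzyl in place of benzodioxinylmethyl on the ester

The compounds below may be only part of what the source reports. "The series", "measured", "known", "first", "only" and "open" are said of these compounds alone.

Compound 1 `C/C=C1/[C@H](O[C@@H]2O[C@H](CO)[C@@H](O)[C@H](O)[C@H]2O)OC=C(C(=O)OC)[C@H]1CC(=O)OCc1ccc2c(c1)OCCO2`: in a functional assay on SK-BR-3 cells (Homo sapiens) for antiproliferative activity, read by MTT assay, with a stated time of 72 h (a higher number here means a weaker inhibitor, a lower number a stronger inhibitor), compound 1 gives > 15000 nM, a limit of the assay.
Compound 2 `C/C=C1/[C@H](O[C@@H]2O[C@H](COC(C)=O)[C@@H](OC(C)=O)[C@H](OC(C)=O)[C@H]2OC(C)=O)OC=C(C(=O)OC)[C@H]1CC(=O)SCCc1ccccc1`: in this assay compound 2 gives > 15000 nM, also a limit.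
Compound 3 `C/C=C1/[C@H](O[C@@H]2O[C@H](CO)[C@@H](O)[C@H](O)[C@H]2O)OC=C(C(=O)O)[C@H]1CC(=O)O`: in this assay compound 3 gives > 50000 nM, again a limit.

None of the three measured compounds yields a number. Compound 1 sits at the limit of > 15000 nM in this assay, at which 2 of the 3 values shown sit, while compound 3 sits at the limit of > 50000 nM in this assay, at which 1 of the 3 values shown sits, so nothing can be said about order among them. Compound 4 `C/C=C1/[C@H](O[C@@H]2O[C@H](CO)[C@@H](O)[C@H](O)[C@H]2O)OC=C(C(=O)OC)[C@H]1CC(=O)OCc1ccccc1` differs from compound 1 by phenyl in place of 2,3-dihydro-1,4-benzodioxin-6-yl on a saturated chain carbon bound to an oxygen next to a carbonyl group. Among the compounds with values here, with no measured step to lean on, the change from compound 1 to compound 4 is expected to give no shift beyond the scatter in this assay. Compound 4 is therefore expected to show 20000 nM, between 8000 nM and 60000 nM. The step from compound 1 to compound 4 is estimated as a step that the limit leaves unreadable from compound 1 to compound 4, and a limit rather than a number is expected.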

Compound 4, half-maximal inhibitory concentration: > 15000 nM
Compound 4 ended at the assay's limit; the forecaster's own chance of this, stated with the estimate: 75%; the middle value lies beyond the limit too.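

In this assay, within the data shown here, compound 1 and compound 4 both end at a limit, so no step between them can be read. The compounds shown, none of which gives a number, leave open whether phenyl and 2,3-dihydro-1,4-benzodioxin-6-yl differ in effect at all.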